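The source may hold more compounds than are shown below. What is called first, only, known or untested is meant among the compounds shown, and "the series" means these compounds.

Measured compounds in a functional assay on HT-29 cells (Homo sapiens) for antiproliferative activity, read by MTT assay, with a stated time of 96 h; on this read-out higher numbers stand for weaker inhibition and lower numbers for stronger inhibition:
- compound 1 `COc1ccc(N2C(=O)NC3(CSC4=C3C(=O)c3ncccc3C4=O)C2=O)cc1` gives 2 nM
- compound 2 `O=C1NNC(=O)C2(CSC3=C2C(=O)c2ncccc2C3=O)N1` gives 1580 nM; 1600 nM; 1600 nM (3 entries)
- compound 3 `O=C1NC(=O)C2(CSC3=C2C(=O)c2ncccc2C3=O)N1` gives 190 nM; 180 nM; 190 nM (3 entries)

Compound 1 has the only single entry in this assay, and its number is the lowest of the three; compound 2 and compound 3 each have repeated entries that agree closely, as the several entries of compound 2 in this assay, 1580 nM; 1600 nM; 1600 nM (3 entries) and the several entries of compound 3 in this assay, 190 nM; 180 nM; 190 nM (3 entries) show. Among the compounds with values here, no pair among the measured compounds differs in one place, so no measured step is available.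

Compound 4 `CCN(CC)c1ccc(N2C(=O)NC3(CSC4=C3C(=O)c3ncccc3C4=O)C2=O)cc1` is the next to be measured in this assay. It differs from compound 1 by diethylamino in place of methoxy on an aromatic carbon. Within the data shown here, with no measured step to lean on, the expected change from compound 1 to compound 4 is small, likely within the scatter, with a slight lean toward weaker inhibition. Compound 4 is expected at 4 nM, between 1 nM and 20 nM. The step this estimate means is a 2.0-fold higher number from compound 1 to compound 4 (0.30 log units; within the scatter).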

Compound 4, half-maximal inhibitory concentration: 50 nM
The estimate for compound 4 lay 13-fold (1.10 log units) below the measured number; the whole stated range lies below it.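

At this position, on an aromatic carbon para to a large group, the substituent matters in this assay: diethylamino in place of methoxy gives a 25-fold higher number from compound 1 to compound 4 (1.40 log units; beyond the scatter). Within the data shown here, this is the only measured step, and it shows that a change at this one place can move the number beyond the scatter. Repeats of another compound in this assay agree closely, so a gap of this size is not read as assay noise: the several entries of compound 2 in this assay, 1580 nM; 1600 nM; 1600 nM (3 entries)

From the compounds shown here alone, whether the heavy-atom count or the nitrogen carries the step stays open. Dimethylamino or ethoxy at this place would separate the two.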